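Methoxy removal on the anilino ring of a thiadiazole series

The source may hold more compounds than are shown below. What is called first, only, known or untested is meant among the compounds shown, and "the series" means these compounds.

Compound 1 `Clc1ccc(Nc2nnc(-c3ccccc3)s2)cc1Cl` gives 6280 nM in an assay on isolated protein for inhibition of beta-glucuronidase (Bos taurus), read by spectrophotometry, with a stated time of 30 min (a lower number here means a stronger inhibitor, a higher number a weaker inhibitor), and has the lowest number of the three measured compounds. Compound 2 `COc1ccccc1-c1nnc(Nc2ccc(Cl)c(Cl)c2)s1` gives 22600 nM in this assay. The two differ by hydrogen in place of methoxy on an aromatic carbon, and the step is a 3.6-fold lower number from compound 2 to compound 1 (0.56 log units; beyond the scatter). Compound 3 `COc1cccc(Nc2nnc(-c3ccc(Br)cc3)s2)c1` gives 31100 nM in this assay; the difference between the core of compound 3 and the core of compound 2 is not broken down here, and the two values lie within the usual scatter of each other, so no order between them is claimed.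

Compound 4 `Brc1ccc(-c2nnc(Nc3ccccc3)s2)cc1` has not yet been measured in this assay. It differs from compound 3 by hydrogen in place of methoxy on an aromatic carbon. For the measured compounds named here, this is the same kind of change as the one from compound 2 to compound 1, but the place is not the same: in compound 2 the methoxy sits ortho to a large group, in compound 3 it sits meta to a large group. Going by the values given here, with only one measured example of this change, and that at a different place, the expected step from compound 3 to compound 4 is taken as smaller than the measured one, estimated at a 2.1-fold lower number from compound 3 to compound 4 (0.32 log units; beyond the scatter), resting on a 3.6-fold lower number from compound 2 to compound 1 (0.56 log units; beyond the scatter). On this basis compound 4 is expected to give about 15000 nM in this assay, with a plausible range from 6000 nM to 40000 nM.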

Compound 4, half-maximal inhibitory concentration: 40200 nM
Compound 4: middle estimate off by 2.7-fold (0.43 log units), on the low side; the measured number lies above the stated range.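

In this assay, hydrogen in place of methoxy on an aromatic carbon, meta to a large group, gives a 1.3-fold higher number from compound 3 to compound 4 (0.11 log units; within the scatter), so no order between these two compounds is claimed. The same change therefore does not carry over as a fixed step from one core to the other: the same change on two cores in this assay, a 3.6-fold lower number (0.56 log units; beyond the scatter) from compound 2 to compound 1 and a 1.3-fold higher number (0.11 log units; within the scatter) from compound 3 to compound 4, 4.7-fold (0.67 log units) apart, beyond the scatter of two such steps

This does not show that the core alone sets the size of the step, since the two pairs differ both in the core and in the place of the methoxy, and with one pair for each case the gap cannot be assigned to either difference or extended into a rule for the series.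

The compounds shown leave open what the change does when the methoxy stands at the same place on both cores, which is the comparison needed to separate the core from the place. Also open, from the compounds shown here alone, is how the same position responds to other groups in place of the methoxy, such as a hydroxyl, an amine or a carboxylic acid, on the core of compound 3 and on the core of compound 2.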